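Isopropoxy for Isopropyl on the Shared Core

The source may report more compounds than this note shows. Statements on the series, on what has been measured and on what is new or still open speak of the compounds shown alone.

Measured compounds:
- Compound 1 `Cc1cc(S(=O)(=O)Nc2ccc3c(c2)CCN(C)CC3)ccc1-c1ccc(Cl)cc1` gives 5.01 nM in an assay on isolated protein for displacement of a labelled ligand from 5-hydroxytryptamine receptor 6 (Homo sapiens), read by radioligand binding; a lower number here means a stronger inhibitor, a higher number a weaker inhibitor.
- Compound 2 `CC(C)c1cc2c(cc1NS(=O)(=O)c1ccc(-c3ccc(Cl)cc3)cc1)CCN(C)CC2` gives 12.6 nM in this assay.
- Compound 3 `CN1CCc2ccc(NS(=O)(=O)c3ccc(-c4ccc(C#N)cc4)cc3)cc2CC1` gives 25.1 nM in this assay.

Among these three numbers, compound 2 holds the second highest. Its gap to compound 3 is within the usual scatter of repeated measurements, so the two cannot be told apart on this evidence. Compound 1, however, gives a lower number than compound 2 by a margin beyond the scatter, so compound 1 is the stronger inhibitor of the pair.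

Compound 4 `CC(C)Oc1cc2c(cc1NS(=O)(=O)c1ccc(-c3ccc(Cl)cc3)cc1)CCN(C)CC2` has not yet been measured. It differs from compound 2 in one place: isopropoxy in place of isopropyl on an aromatic carbon. The place is on an aromatic carbon of a six-membered aromatic ring of carbon only, part of a fused system of two rings, ortho to a large group, meta to a fused ring and para to a fused ring.

For the measured compounds named here, no pair of measured compounds shows this exact change, so the expected step from compound 2 to compound 4 in this assay rests on the change alone; a small step, a 1.2-fold higher number from compound 2 to compound 4 (0.08 log units; within the scatter), in either direction and not clearly beyond the scatter is expected. Compound 4 is therefore estimated at 15 nM, with a range from 5 nM to 45 nM.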

Compound 4, inhibition constant: 31.6 nM
The estimate for compound 4 lay 2.1-fold (0.32 log units) below the measured number, and the stated range covers the measured number.
By their numbers in this assay, from the lowest: compound 1; then compounds 2, 3 and 4 (each within the scatter of the next, the first and the last beyond it).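

At this aromatic carbon, ortho to a large group, putting isopropoxy in place of isopropyl gives a 2.5-fold higher number from compound 2 to compound 4 (0.40 log units; beyond the scatter) in this assay. For the compounds shown here, this is the first single-place comparison, and it shows that the position does not treat these two similar-looking groups alike: the change makes the inhibitor modestly weaker, by a step beyond the scatter. Nothing available explains why the step runs in this direction.

The entering group differs from the leaving one by a single oxygen, which also counts as a hydrogen-bond acceptor, and this one pair cannot show whether that oxygen or the larger group as a whole matters. Also open, going by these compounds, is where a methoxy group or an amine on this same carbon would fall relative to compound 2 and compound 4.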